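Hydroxy in place of bromo in a small series

The source may hold more compounds than are shown below. What is called first, only, known or untested is meant among the compounds shown, and "the series" means these compounds.

Compound 1 `COc1cccc(/C=C2\CCC/C(=C\c3ccc(O)c(O)c3)C2=O)c1OC` gives 17900 nM as its value
Compound 2 `COc1ccc(/C=C2\CCC/C(=C\c3cccc(Br)c3)C2=O)cc1OC` gives 12400 nM as its value

For the measured compounds named here, both numbers come from an ADME assay on NHDF cells (Homo sapiens) for cytotoxicity, read by MTT assay, with a stated time of 72 h (on this read-out higher numbers stand for weaker inhibition and lower numbers for stronger inhibition), and lie within the scatter of each other, so compound 2 stands level with compound 1, the only other measured compound. Going by the values given here, these two differ in more than one place, and the series offers no measured step at a single place.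

Compound 3 `COc1ccc(/C=C2\CCC/C(=C\c3cccc(O)c3)C2=O)cc1OC` is the next to be read. It departs from compound 2 by hydroxy in place of bromo on an aromatic carbon, meta to a large group.

Compound 1 also carries hydroxy on an aromatic carbon, and compound 1 at 17900 nM is not separated from compound 2, though this is no clean comparison. With so little to go on, no change beyond the scatter is expected, with at most a slight drift toward weaker inhibition. The expected size is a 1.5-fold higher number from compound 2 to compound 3 (0.16 log units; within the scatter) as an estimate only. The estimate for compound 3 is 18000 nM, with an expected range from 7000 nM to 45000 nM on this read-out.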

Compound 3, half-maximal inhibitory concentration: 6800 nM
For compound 3 the middle estimate is 2.6-fold (0.42 log units) above the measured one; measured number outside the range, below it.
By their numbers in this assay, from the lowest: compounds 3, 2 and 1 (each within the scatter of the next, the first and the last beyond it).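

In this assay, for the compounds shown here, the exchange of 3-bromophenyl for 3-hydroxyphenyl supplies the first step that can be read at a single place, and it amounts to a 1.8-fold lower number from compound 2 to compound 3 (0.26 log units; within the scatter). At this aromatic carbon, meta to a large group, compound 2 and compound 3 therefore stand level on this read-out, even though the exchange adds a hydrogen-bond donor and a hydrogen-bond acceptor. No measurement in hand accounts for this result.

This single step does not show whether other groups at the same carbon, such as an amine, a carboxylic acid or a fluoro group, would also stay level with compound 2 and compound 3. The compounds shown also leave open whether the exchange of bromo for hydroxy would read the same way with the methoxy groups arranged as in compound 1, and whether the level result holds on any read-out other than this assay.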